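Moving the Fluorine on the Phenyl Ring

A few compounds are considered here, and "the series" means these few. Any claim that something is new, unique, unknown or untested is made for them only; others in the source may bear on it.

Compound 2 `CNC(=O)c1cc(Oc2ccc(NC(=O)c3nn(-c4cccc(F)c4)c(=O)cc3C)cc2F)ccn1` gives 6410 nM in a functional assay on MCF7 cells (Homo sapiens) for cytotoxicity, read by MTT assay, with a stated time of 72 h (a lower number here means a stronger inhibitor, a higher number a weaker inhibitor), the lowest of the two numbers measured; compound 1 `CNC(=O)c1cc(Oc2ccc(NC(=O)c3nn(-c4ccccc4C(F)(F)F)c(=O)cc3C)cc2F)ccn1` gives 35700 nM, and the step of a 5.6-fold lower number from compound 1 to compound 2 (0.75 log units; beyond the scatter) is the only one known. Compound 3 `CNC(=O)c1cc(Oc2ccc(NC(=O)c3nn(-c4ccccc4F)c(=O)cc3C)cc2F)ccn1` differs from compound 2 by 2-fluorophenyl in place of 3-fluorophenyl on an aromatic nitrogen. That one measured step changes both the group on the phenyl and its place, so it bears only loosely on the present change. Compound 3 is expected to show a modest rise, a 1.9-fold higher number from compound 2 to compound 3 (0.27 log units; within the scatter). Compound 3 is therefore estimated at 12000 nM, within 4000 nM to 40000 nM.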

Compound 3, half-maximal inhibitory concentration: > 40000 nM
Compound 3 ended at the assay's limit; the forecaster's own chance of this, stated with the estimate: 5%; at least 3.3-fold (0.52 log units) between middle value and limit.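

Compound 2 and compound 3 have the same atoms, so this step isolates the place of the fluorine alone: 2-fluorophenyl in place of 3-fluorophenyl gives an at least 6.2-fold higher number from compound 2 to compound 3 (0.79 log units; beyond the scatter). Compound 3 carries a limit, not a number: the limit of > 40000 nM in this assay, at which 1 of the 3 values shown sits. Its other step, an at least 1.1-fold higher number from compound 1 to compound 3 (0.04 log units; that floor lies within the scatter), cannot be read as a real difference, so fluoro and trifluoromethyl at this place remain unordered.

On these data alone, how far compound 3 lies past the limit stays unknown. So does how a 4-fluorophenyl or a plain phenyl group would compare with the 3-fluorophenyl of compound 2.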